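Triazolylmethyl amides: aryl to benzyl swap at the triazole

A few compounds are considered here, and "the series" means these few. Any claim that something is new, unique, unknown or untested is made for them only; others in the source may bear on it.

Compound 1 `Cc1ccc(-n2cc(CNC(=O)c3cccc4c3cnn4C(C)C)nn2)c(C)c1` carries a 2,4-dimethylphenyl on the triazole nitrogen. In a functional assay on MCF7 cells (Homo sapiens) for inhibition, read by MTT assay, with a stated time of 72 h (on this read-out higher numbers stand for weaker inhibition and lower numbers for stronger inhibition), compound 1 gives only a limit, > 40000 nM. Compound 2 `Cc1ccc(-n2cc(CNC(=O)c3cccc4c3cnn4C(C)C)nn2)cc1` retains a 4-methylphenyl at the same nitrogen. In this assay compound 2 likewise reaches only a limit, > 40000 nM. Compound 3 `CC(C)n1ncc2c(C(=O)NCc3cn(-c4ccccc4F)nn3)cccc21` has the 2-fluorophenyl in this position. In this assay compound 3 also gives only a limit, > 40000 nM. Among the measured compounds shown here, because all three values sit at the limit of > 40000 nM in this assay, at which 3 of the 3 values shown sit, none of the measured steps can be read: from compound 1 to compound 2 a step that the two limits leave unreadable from compound 1 to compound 2, from compound 1 to compound 3 a step that the two limits leave unreadable from compound 1 to compound 3, and from compound 2 to compound 3 a step that the two limits leave unreadable from compound 2 to compound 3. Compound 3 therefore stands where every measured member of the series stands, at the limit, with no resolved difference among them.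

Compound 4 `COc1ccc(Cn2cc(CNC(=O)c3cccc4c3cnn4C(C)C)nn2)cc1` changes the substituent on the triazole nitrogen: 4-methoxybenzyl in place of 2-fluorophenyl on an aromatic nitrogen. For the measured compounds named here, no measured step bears on this change, since the aryl-to-benzyl swap has no precedent here and the three steps that exist are unreadable. With every measured compound at the limit, the step from compound 3 to compound 4 is expected to be a number no higher from compound 3 to compound 4 (the limit leaves the size open), most likely again beyond the assay window. Compound 4 is estimated at 40000 nM in this assay, with a range of 15000 nM to 100000 nM.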

Compound 4, half-maximal inhibitory concentration: > 40000 nM
Compound 4: a limit, no number; the forecaster's own chance of this, stated with the estimate: 80%; the middle value lies on the limit itself.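

In this assay compound 4 gives only a limit, > 40000 nM. The steps from compound 1, compound 2 and compound 3 to compound 4 therefore cannot be read, as every value is a limit: the limit of > 40000 nM in this assay, at which 4 of the 4 values shown sit.

The compounds shown leave open how 4-methoxybenzyl and the three aryl groups on the aromatic nitrogen rank, and which group there, if any, would give a readable number.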